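A few compounds are considered here, and "the series" means these few. Any claim that something is new, unique, unknown or untested is made for them only; others in the source may bear on it.

Measured compounds in a functional assay on MOLT-4 cells (Homo sapiens) for inhibition; on this read-out lower numbers stand for stronger inhibition and higher numbers for weaker inhibition:

- compound 1 `O=C1/C(=C/c2cccc(Br)c2)Cc2ccccc21`: 173000 nM
- compound 2 `O=C1/C(=C/c2ccccc2)CCc2ccccc21`: 32400 nM
- compound 3 `O=C1/C(=C/c2cccc(F)c2)CCc2ccccc21`: 11900 nM

Compound 2 stands second highest of the three numbers in this assay; compound 3 sits nearest to it with a lower number, while compound 1 gives the highest number of the set. Compound 1 also carries a different core from compounds 2 and 3, so its value shows only that, not a single-point step.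

The unmeasured compound 4 `O=C1/C(=C/c2ccc(Br)cc2)CCc2ccccc21` differs from compound 2 in one place: bromo in place of hydrogen on an aromatic carbon. Going by the values given here, the only measured step that bears on this change is a halogen entering an aromatic carbon of the same ring, a 2.7-fold lower number from compound 2 to compound 3 (0.43 log units; beyond the scatter), a modest lowering. That step concerns fluoro at another position, not bromo para to a large group, so it is a weak guide. The expectation is a small step in this assay, either direction, most likely not beyond the scatter. The estimated step of a 1.3-fold lower number from compound 2 to compound 4 (0.11 log units; within the scatter) is expected to be small. Compound 4 is therefore expected to give about 25000 nM (range 8000 nM to 80000 nM).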

Compound 4, half-maximal inhibitory concentration: > 500000 nM
Compound 4: a limit, no number; the forecaster's own chance of this, stated with the estimate: 10%; middle value at least 20-fold (1.30 log units) away from the limit.
By their numbers in this assay, from the lowest: compound 3; then compound 2; then compound 1. At a limit, above all of these: compound 4.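

In this assay compound 4 gives > 500000 nM, which is a limit and not a number. With bromo para to a large group, the series shows an at least 15-fold higher number from compound 2 to compound 4 (1.18 log units; beyond the scatter), so a halogen entering this ring does not always lower the number, as the earlier fluoro step alone suggested: a 2.7-fold lower number from compound 2 to compound 3 (0.43 log units; beyond the scatter) runs the opposite way. The size of the new step is only a bound, and the true value of compound 4 is not fixed: the limit of > 500000 nM in this assay, at which 1 of the 4 values shown sits.

The compounds shown do not separate the identity of the halogen from its place, as bromo and fluoro sit at different places on this ring in compound 4 and compound 3. As far as these compounds go, how a methoxy group or an amine at the place of the bromo would read in this assay also remains open.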